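Cyclobutyl in place of 2-hydroxybutyl on the amide

The source may hold more compounds than are shown below. What is called first, only, known or untested is meant among the compounds shown, and "the series" means these compounds.

In an ADME assay on microsomes from liver (Homo sapiens) for metabolic stability, read by LC-MS, using NADPH, with a stated time of 120 min, tested at 1 uM (a lower number here means that the compound disappears faster, a higher number that the compound lasts longer), compound 1 `COc1cccc(OC)c1-c1cc(C(=O)N[C@@H](CCC2CCCCC2)CC(=O)O)nn1-c1ccc(F)cc1` gives 3.83 h. Compound 2 `CC[C@@H](O)CNC(=O)C[C@H](CCC1CCCCC1)NC(=O)c1cc(-c2c(OC)cccc2OC)n(CC(C)C)n1` gives 0.0517 h, and compound 3 `CCC(=O)CNC(=O)C[C@H](CCC1CCCCC1)NC(=O)c1cc(-c2c(OC)cccc2OC)n(CC(C)C)n1` gives 0.0592 h. Compound 2 therefore stands level with compound 3 at the low end of the numbers, and beyond the scatter from compound 1. Compound 4 `COc1cccc(OC)c1-c1cc(C(=O)N[C@@H](CCC2CCCCC2)CC(=O)NC2CCC2)nn1CC(C)C` has not yet been measured. It departs from compound 2 in one place: cyclobutyl in place of 2-hydroxybutyl on an amide-type nitrogen. Compound 1 differs from compound 2 in more than one place, so the gap between them gives no measure of this change. Going by the values given here, the one measured step on this side chain is a 1.1-fold higher number from compound 2 to compound 3 (0.06 log units; within the scatter). That step does not involve a cyclobutyl group, so it is only indirect evidence and the range is kept wide. On that evidence, the expected step in this assay is a 1.2-fold higher number from compound 2 to compound 4 (0.06 log units; within the scatter), with no change beyond the scatter anticipated. The estimated half-life of compound 4 is 0.06 h, with an expected range from 0.025 h to 0.15 h.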

Compound 4, half-life: 0.0543 h
Estimate against measurement, compound 4: 1.1-fold (0.04 log units) above, within the range that was stated.
By their numbers in this assay, from the lowest: compounds 2, 4 and 3 (each within the scatter of the next); then compound 1.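

In this assay, going by these compounds alone, the new compound adds a ring to a side chain that had so far only been varied as an open chain: the cyclobutyl amide shows a 1.1-fold higher number from compound 2 to compound 4 (0.02 log units; within the scatter), and against the propanoylmethyl amide it shows a 1.1-fold lower number from compound 3 to compound 4 (0.04 log units; within the scatter). Losing the hydrogen-bond donor, the hydrogen-bond acceptor and the defined stereocentre of 2-hydroxybutyl, and gaining a four-membered ring of carbon only, therefore leaves the half-life within the scatter at this amide-type nitrogen. No supporting data are available to explain this result.

The compounds shown do not reveal whether any group on this nitrogen can move the half-life beyond the scatter. An amine-bearing chain or a longer alkyl chain in place of cyclobutyl remains an open case.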